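Methyl to 4,4-difluorocyclohexyl on an amine nitrogen

The compounds below may be only part of what the source reports. "The series", "measured", "known", "first", "only" and "open" are said of these compounds alone.

Of the compounds shown here, two have been measured so far: compound 1 `NCCCCN(C[C@H]1Cc2ncccc2CN1)[C@H]1CCCc2cccnc21` and compound 2 `CN(C)CCCCN(C[C@H]1Cc2ncccc2CN1)[C@H]1CCCc2cccnc21`. In an ADME assay on microsomes from liver (Homo sapiens) for metabolic stability, using NADPH, with a stated time of 10 min (on this read-out lower numbers stand for a less stable compound and higher numbers for a more stable compound), compound 1 gives 100% and compound 2 gives 100% at the end of the incubation, so compound 2 stands level with compound 1.

Compound 3 `CN(CCCCN(C[C@H]1Cc2ncccc2CN1)[C@H]1CCCc2cccnc21)C1CCC(F)(F)CC1` is the next to be read. The structural change is 4,4-difluorocyclohexyl in place of methyl on an amine nitrogen and amounts to 4,4-difluorocyclohexyl in place of methyl on an amine nitrogen.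

Among the compounds with values here, one measured step bears on this, and only loosely: no change at the digits printed from compound 1 to compound 2 (within the scatter) for dimethylamino in place of amino on a saturated chain carbon. Within the data shown here, no measured compound carries a ring or fluorine on this amine nitrogen, so the series gives no direct guide to the new group. Compound 2 at 100% leaves room for movement in one direction only. The estimated step of a number 10 percentage points lower from compound 2 to compound 3 (within the scatter) is a modest expected fall in this assay that may stay within the scatter. Compound 3 is estimated at 90% within an expected range from 70% to 100% as the working figure.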

Compound 3, percent of the compound remaining: 61%
Compound 3: middle estimate off by 29 percentage points, on the high side; the whole stated range lies above it.
By their numbers in this assay, from the lowest: compound 3; then compounds 1 and 2 (each within the scatter of the next).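

On the amine nitrogen whose other neighbours are saturated chain carbons, 4,4-difluorocyclohexyl in place of methyl gives a number 39 percentage points lower from compound 2 to compound 3 (beyond the scatter) in this assay, so this position is not indifferent to its substituent, which the earlier pair alone could not show. Measured from the primary amine, the larger replacement gives a number 39 percentage points lower from compound 1 to compound 3 (beyond the scatter), and the amino and dimethylamino compounds, level at the digits printed, now stand together against compound 3 on this read-out. No measurement at hand accounts for the fall.

The compounds shown do not separate the contribution of the ring from that of the two fluorines, and a plain cyclohexyl on this nitrogen would divide the step into those two parts. On these data alone, how the read-out depends on the size and shape of the group also remains open, since an isopropyl, a cyclopropyl or a tetrahydropyran-4-yl at the same place could show whether a smaller carbon group or a ring oxygen gives a read-out closer to that of compound 2.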